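Trading the aryl group for a short chain

The source may report more compounds than this note shows. Statements on the series, on what has been measured and on what is new or still open speak of the compounds shown alone.

In a functional assay on Bel7402/5-FU cells (Homo sapiens) for antiproliferative activity, read by MTT assay, with a stated time of 72 h (on this read-out lower numbers stand for stronger inhibition and higher numbers for weaker inhibition), compound 3 `C=C1C(=O)O[C@H]2[C@H]1CC/C(COC(=O)Cn1cc(F)c(=O)n(Cc3ccc(F)c(F)c3)c1=O)=C\CC[C@@]1(C)O[C@@H]21` gives 4480 nM, compound 1 `C=C1C(=O)O[C@H]2[C@H]1CC/C(COC(=O)Cn1cc(F)c(=O)n(Cc3ccc(Br)cc3)c1=O)=C\CC[C@@]1(C)O[C@@H]21` gives 3240 nM and compound 2 `C=C1C(=O)O[C@H]2[C@H]1CC/C(COC(=O)Cn1cc(F)c(=O)n(Cc3ccc(F)cc3F)c1=O)=C\CC[C@@]1(C)O[C@@H]21` gives 5010 nM. Compound 3 therefore stands within the scatter of both others, with a 1.4-fold higher number from compound 1 to compound 3 (0.14 log units; within the scatter) and a 1.1-fold lower number from compound 2 to compound 3 (0.05 log units; within the scatter). Compound 4 `C=C1C(=O)O[C@H]2[C@H]1CC/C(COC(=O)Cn1cc(F)c(=O)n(CCC)c1=O)=C\CC[C@@]1(C)O[C@@H]21` carries this change: ethyl in place of 3,4-difluorophenyl on a saturated chain carbon bound to an aromatic nitrogen. The remaining measured step, a 1.5-fold higher number from compound 1 to compound 2 (0.19 log units; within the scatter), is also within the scatter. All three steps exchange one substituted phenyl for another, so none tests the loss of the ring, and the range stays wide. No shift beyond the scatter is expected, and the expected step is a 1.2-fold higher number from compound 3 to compound 4 (0.09 log units; within the scatter). The estimate for compound 4 is 5500 nM, with an expected range of 2200 nM to 14000 nM.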

Compound 4, half-maximal inhibitory concentration: 9110 nM
For compound 4 the middle estimate is 1.7-fold (0.22 log units) below the measured one, within the range that was stated.
By their numbers in this assay, from the lowest: compounds 1, 3, 2 and 4 (each within the scatter of the next, the first and the last beyond it).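

Among the compounds shown here, removing the aryl ring gives the first steps beyond the scatter in this assay, a 2.0-fold higher number from compound 3 to compound 4 (0.31 log units; beyond the scatter) and a 2.8-fold higher number from compound 1 to compound 4 (0.45 log units; beyond the scatter), although both are modest, while a 1.8-fold higher number from compound 2 to compound 4 (0.26 log units; within the scatter) remains within it. Ethyl in place of the aryl group on this saturated chain carbon is therefore not neutral against every aryl partner, and compound 2 is the exception. No measurement on hand accounts for this shift. Open, as far as these compounds go, is whether a longer chain such as butyl, or a terminal amine or carboxylic acid on the propyl chain, would change the number in this assay.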